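A Methoxymethoxy Group on a Compound at the Assay Limit

This account rests on a few compounds, and the source may have more. Where it says the series, first, only, none or still open, it means among the compounds named here.

Compound 1 `COc1ccc(C2=C(c3cc(OC)c(OC)c(OC)c3)C(=O)CC2O[SiH2]C(C)(C)C)cc1`: > 100 ug/mL
Compound 2 `COc1ccc(OC)c(C2=C(c3cc(OC)c(OC)c(OC)c3)C(=O)CC2O[SiH2]C(C)(C)C)c1`: > 100 ug/mL
Compound 3 `COc1ccc(C2=C(c3cc(OC)c(OC)c(OC)c3)C(=O)CC2O[SiH2]C(C)(C)C)cc1OC`: > 100 ug/mL

In an ADME assay on MIA PaCa-2 cells (Homo sapiens) for cytotoxicity, read by MTT assay, with a stated time of 72 h (a higher number here means a weaker inhibitor, a lower number a stronger inhibitor), compound 3 gives > 100 ug/mL, which is a limit of the assay and not a number. The series offers no firmer reference point: the limit of > 100 ug/mL in this assay, at which 3 of the 3 values shown sit.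

Compound 4 `COCOc1cc(C2=C(c3cc(OC)c(OC)c(OC)c3)C(=O)CC2O[SiH2]C(C)(C)C)ccc1OC` carries methoxy in place of hydrogen on a saturated chain carbon bound to an oxygen on an aromatic ring, which turns methoxy to methoxymethoxy. The nearest evidence is a step that the two limits leave unreadable from compound 1 to compound 3, a methoxy change on the aromatic ring, along with a step that the two limits leave unreadable from compound 2 to compound 3 and a step that the two limits leave unreadable from compound 1 to compound 2. None of these gives a size or direction, so no step beyond the scatter is expected in this assay. The expected change is a step that the limit leaves unreadable from compound 3 to compound 4. Compound 4 is expected to sit at the limit again, and its estimated value is 130 ug/mL, within an estimated range of 60 ug/mL to 300 ug/mL.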

Compound 4, half-maximal inhibitory concentration: 50 ug/mL
Beside the measured number, compound 4's estimate is 2.6-fold (0.41 log units) above it; measured number outside the range, below it.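

Methoxy on a saturated chain carbon bound to an oxygen on an aromatic ring is the only change shown that brings a compound off the limit in this assay, giving an at least 2.0-fold lower number from compound 3 to compound 4 (0.30 log units; that floor lies within the scatter), together with an at least 2.0-fold lower number from compound 2 to compound 4 (0.30 log units; that floor lies within the scatter) and an at least 2.0-fold lower number from compound 1 to compound 4 (0.30 log units; that floor lies within the scatter). Each of these is a floor and not a size, and the steps among compound 1, compound 2 and compound 3 cannot be read. Compound 4 is therefore the only firm number in the series, and the other compounds offer only this: the limit of > 100 ug/mL in this assay, at which 3 of the 4 values shown sit.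

As far as these compounds go, how large the step truly is stays open. So does whether a hydroxyl or a longer chain such as ethoxymethoxy at this oxygen would also give a number in this assay.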